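This account rests on a few compounds, and the source may have more. Where it says the series, first, only, none or still open, it means among the compounds named here.

Compound 2 `O=C(Nc1cccc(-n2cc(-c3ccncc3)c(-c3cc(O)cc(Cl)c3)n2)c1)Nc1ccc(Cl)c(Cl)c1` gives 103% in a functional assay on RPMI-8226 cells (Homo sapiens) for inhibition, read by sulforhodamine B assay, with a stated time of 48 h, tested at 0.1 uM (a lower number here means a stronger effect, a higher number a weaker effect of the compound at the concentration tested), close to compound 1 `O=C(Nc1cccc(-n2cc(-c3ccncc3)c(-c3cc(O)cc(Cl)c3)n2)c1)Nc1ccc(Cl)c(C(F)(F)F)c1`, which gives 101%, and apart from compound 3 `COc1cc(Cl)cc(-c2nn(-c3cccc(NC(=O)Nc4cc(C(F)(F)F)cc(C(F)(F)F)c4)c3)cc2-c2ccncc2)c1`, which gives 87%. Among the compounds with values here, the only single-point step measured, a number 2 percentage points higher from compound 1 to compound 2 (within the scatter), swaps chloro for trifluoromethyl on an aromatic carbon and so does not bear on the change to compound 4 `COc1cc(Cl)cc(-c2nn(-c3cccc(NC(=O)Nc4ccc(Cl)c(Cl)c4)c3)cc2-c2ccncc2)c1`: methyl in place of hydrogen on an oxygen on an aromatic ring. Compound 3 carries a methoxy group but differs from compound 1 in more than one place, so its number alone cannot settle this step. Within the data shown here, with no measured step to lean on, the expected step of a number 6 percentage points lower from compound 2 to compound 4 (within the scatter) is small, and compound 4 is estimated at 97%, between 82% and 110%.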

Compound 4, a percentage reported as activity, at one concentration (the size of the read-out at that concentration, not a potency): 100%
The estimate for compound 4 lay 3 percentage points below the measured number, and the stated range covers the measured number.
By their numbers in this assay, from the lowest: compound 3; then compounds 4, 1 and 2 (each within the scatter of the next).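

In this assay, the change from 3-chloro-5-hydroxyphenyl to 3-chloro-5-methoxyphenyl gives a number 3 percentage points lower from compound 2 to compound 4 (within the scatter). Within the data shown here, this is the first direct reading of this change, with the rest of the molecule held constant, and it shows that a methyl group on this oxygen leaves the read-out within the usual scatter. Nothing available explains this result. From the compounds shown here alone, an ethoxy group or a longer chain on this oxygen remains open, as does an amine in its place. Going by these compounds, the hydroxy counterpart of compound 3 also remains open.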